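Swapping the Amide Ring from Pyridine to Thiadiazole

A few compounds are considered here, and "the series" means these few. Any claim that something is new, unique, unknown or untested is made for them only; others in the source may bear on it.

The shared core of the series appears in compound 1, `CNC(=O)[C@H](c1ccc(Cl)cc1)C(C)C`, which in a functional assay on CHO cells for agonist activity at Free fatty acid receptor 2 (Homo sapiens), read by cAMP accumulation (a higher number here means a larger maximal response, a lower number a smaller maximal response), gives 66%. Compound 2, `CC(C)[C@H](C(=O)Nc1ccccc1)c1ccc(Cl)cc1`, has phenyl in place of methyl on the amide-type nitrogen. In this assay compound 2 reaches only < 30%, which is a limit of the assay rather than a number (the limit of < 30% in this assay, at which 1 of the 3 values shown sits). Compound 3, `CC(C)[C@H](C(=O)Nc1ccccn1)c1ccc(Cl)cc1`, carries pyridin-2-yl in the same place and gives 92% in this assay, the highest of the two numbers measured; the step of a number 26 percentage points higher from compound 1 to compound 3 (beyond the scatter) separates it from compound 1, and the step of a number at least 62 percentage points higher from compound 2 to compound 3 (beyond the scatter) separates it from compound 2. Together with the step of a number at least 36 percentage points lower from compound 1 to compound 2 (beyond the scatter), these show that the response depends strongly on which group sits on the amide-type nitrogen.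

Compound 4, `CC(C)[C@H](C(=O)Nc1ncns1)c1ccc(Cl)cc1`, differs from compound 3 by the change (1,2,4-thiadiazol-5-yl in place of pyridin-2-yl on an amide-type nitrogen). Both groups are aromatic rings with hydrogen-bond acceptors and no donor, so the change is smaller in kind than the steps measured so far. A modest decrease, a number 22 percentage points lower from compound 3 to compound 4 (beyond the scatter), is expected. Compound 4 is estimated at 70%, with a range from 40% to 95%.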

Compound 4, largest response reached (reported as efficacy), in percent of the reference or control that the assay uses: 99%
The estimate for compound 4 lay 29 percentage points below the measured number; measured number outside the range, above it.
By their numbers in this assay, from the lowest: compound 1; then compounds 3 and 4 (each within the scatter of the next). At a limit, below all of these: compound 2.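

In this assay, the change on the amide-type nitrogen gives a number 7 percentage points higher from compound 3 to compound 4 (within the scatter), so a five-membered aromatic ring with 3 hetero atoms and a six-membered aromatic ring with 1 hetero atom cannot be told apart at this position. The 1,2,4-thiadiazol-5-yl group also gives a number 33 percentage points higher from compound 1 to compound 4 (beyond the scatter), which shows that the higher response over methyl is not confined to pyridin-2-yl, although phenyl, also an aromatic ring, goes against any rule covering aromatic rings as a whole. The value of compound 2 is a limit and not a number, so the step of a number at least 69 percentage points higher from compound 2 to compound 4 (beyond the scatter) gives only a minimum size: the limit of < 30% in this assay, at which 1 of the 4 values shown sits.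

From the compounds shown here alone, whether a thiazol-2-yl or a pyrimidin-2-yl ring on the same nitrogen would give a response like those of compound 3 and compound 4 remains open, as does the effect of a carboxylic acid elsewhere on the shared core. The largest response also leaves open whether compound 3 and compound 4 need similar concentrations to reach it.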